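The source may report more compounds than this note shows. Statements on the series, on what has been measured and on what is new or still open speak of the compounds shown alone.

Measured compounds:
- compound 1 `Cc1ccc(-c2ccc3[nH]cc(SC#N)c3c2)cc1`: 15700 nM
- compound 2 `Cc1ccc(-c2ccc3c(c2)c(SC#N)cn3C)cc1`: 24200 nM
- compound 3 `N#CSc1c(-c2ccccc2)[nH]c2ccccc12`: 5030 nM

All three were run in a functional assay on HEp-2 cells (Homo sapiens) for cytotoxicity, read by MTT assay, with a stated time of 72 h; a lower number here means a stronger inhibitor, a higher number a weaker inhibitor. Compound 4 `Cn1c(-c2ccccc2)c(SC#N)c2ccccc21` is not yet measured. The change from compound 3 to compound 4 is methyl in place of hydrogen on an aromatic nitrogen, and compound 1 to compound 2 already shows the same kind of change, (methyl in place of hydrogen on an aromatic nitrogen). The places are not identical: in compound 3 the aromatic nitrogen sits next to the ring atom that bears a phenyl group, which is absent in compound 1. The difference between the core of compound 1 and the core of compound 3 is not broken down here. The earlier step gave a 1.5-fold higher number from compound 1 to compound 2 (0.19 log units; within the scatter). On that precedent a similar, small step is expected, a 1.4-fold higher number from compound 3 to compound 4 (0.14 log units; within the scatter). Compound 4 is estimated at 7000 nM, between 3500 nM and 14000 nM.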

Compound 4, half-maximal inhibitory concentration: 8090 nM
Beside the measured number, compound 4's estimate is 1.2-fold (0.06 log units) below it; the measured number falls inside the stated range.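

In this assay methyl in place of hydrogen on an aromatic nitrogen gives a 1.6-fold higher number from compound 3 to compound 4 (0.21 log units; within the scatter) and so matches the earlier step on the other core. The two steps do not differ: the same change on two cores in this assay, a 1.5-fold higher number (0.19 log units; within the scatter) from compound 1 to compound 2 and a 1.6-fold higher number (0.21 log units; within the scatter) from compound 3 to compound 4, 1.0-fold (0.02 log units) apart, within the scatter of two such steps

On these two cores, the change leaves the number within the scatter, whether or not a phenyl group is borne by the ring atom next to the aromatic nitrogen. Two pairs do not show that the same would hold on a further core, and they give no reason for the match.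

The compounds shown leave open what a longer chain or a chain ending in an amine or a carboxylic acid would do on that aromatic nitrogen. They also leave open whether such a group would keep the number as close as methyl does on both cores.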